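A few compounds are considered here, and "the series" means these few. Any claim that something is new, unique, unknown or untested is made for them only; others in the source may bear on it.

Compound 1 `Nc1ccccc1NC(=O)/C=C/c1ccc(CSc2ccc(Cl)cc2)cc1`: 48.2%
Compound 2 `CCc1ccc(SCc2ccc(/C=C/C(=O)Nc3ccccc3N)cc2)cc1`: 58.4%
Compound 3 `Nc1ccccc1NC(=O)/C=C/c1ccc(CSc2ccc(C(F)(F)F)cn2)cc1`: 3.96%

In a functional assay on A-375 cells (Homo sapiens) for inhibition, read by CCK-8 assay, with a stated time of 72 h, tested at 8 uM (on this read-out higher numbers stand for more inhibition of growth at the one concentration tested and lower numbers for less inhibition of growth), compound 3 stands lowest of the three, at 3.96%. Compound 4 `Nc1ccccc1NC(=O)/C=C/c1ccc(CSc2ccc(F)cc2)cc1` has 4-fluorophenyl in place of 5-(trifluoromethyl)pyridin-2-yl on a sulfur. Two measured steps make the same kind of exchange in the opposite direction, and both are large: a number 44.2 percentage points lower from compound 1 to compound 3 (beyond the scatter) and a number 54.4 percentage points lower from compound 2 to compound 3 (beyond the scatter). Changing the substituent on the phenyl ring mattered less, giving the modest a number 10.2 percentage points higher from compound 1 to compound 2 (beyond the scatter). Among the measured compounds shown here, no fluoro compound has been measured yet, so a large rise is expected by analogy only. The expected step is a number 41 percentage points higher from compound 3 to compound 4 (beyond the scatter). The estimate for compound 4 is 45%, with an expected range of 27% to 60%.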

Compound 4, percent growth inhibition at one concentration: 24.6%
Compound 4: middle estimate off by 20.4 percentage points, on the high side, and the stated range ends above it.
By their numbers in this assay, from the lowest: compound 3; then compound 4; then compound 1; then compound 2.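

In this assay, 4-fluorophenyl on the sulfur recovers only part of the loss seen with 5-(trifluoromethyl)pyridin-2-yl (a number 20.6 percentage points higher from compound 3 to compound 4 (beyond the scatter)), so a ring of carbon only does not by itself bring back the level of compound 1 or compound 2. The single substituent on the phenyl ring matters more than the earlier pair suggested (a number 23.6 percentage points lower from compound 1 to compound 4 (beyond the scatter); a number 33.8 percentage points lower from compound 2 to compound 4 (beyond the scatter)), with fluoro, chloro and ethyl rising in that order. Nothing measured here explains these differences. Going by these compounds, it remains open whether a longer chain such as propyl or a methoxy group would continue this rise, and whether the pyridine ring or the trifluoromethyl group accounts for the low value of compound 3.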